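This account rests on a few compounds, and the source may have more. Where it says the series, first, only, none or still open, it means among the compounds named here.

Measured in a functional assay on COR-L23 cells (Homo sapiens) for antiproliferative activity, read by CellTiter-Glo, with a stated time of 72 h; on this read-out higher numbers stand for weaker inhibition and lower numbers for stronger inhibition:
- compound 1 `C[C@@H](c1ccc(NC(=O)N2CC(c3ccc(N)nc3)C2)cc1)N1Cc2ccccc2C1=O`: 19 nM
- compound 2 `C[C@H](NC(=O)C1CCOCC1)c1ccc(NC(=O)N2CC(c3ccc(N)nc3)C2)cc1`: 110 nM

Compound 2 holds the higher of the two numbers, at 110 nM. Compound 3 `CCC(=O)N[C@@H](C)c1ccc(NC(=O)N2CC(c3ccc(N)nc3)C2)cc1` comes next, with ethyl in place of oxan-4-yl on a carbonyl carbon, in short ethyl in place of oxan-4-yl on a carbonyl carbon. Going by the values given here, no measured step isolates this change. Among the compounds with values here, the only step bearing on it is a 5.8-fold higher number from compound 1 to compound 2 (0.76 log units; beyond the scatter), a modest one that exchanged the whole group containing the present oxan-4-yl. The present change replaces only part of that group, so a step no larger is expected in this assay. It may lean slightly towards a higher number, although a single step gives weak support for any direction. The expected change is a 1.5-fold higher number from compound 2 to compound 3 (0.16 log units; within the scatter). For compound 3 the estimated value is 160 nM, with an expected range of 55 nM to 450 nM.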

Compound 3, half-maximal inhibitory concentration: 120 nM
Beside the measured number, compound 3's estimate is 1.3-fold (0.12 log units) above it; measured number inside the range.
By their numbers in this assay, from the lowest: compound 1; then compounds 2 and 3 (each within the scatter of the next).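

In this assay the carbonyl carbon whose other neighbour is an amide-type nitrogen carries oxan-4-yl in compound 2 and ethyl in compound 3, and the two cannot be told apart (a 1.1-fold higher number from compound 2 to compound 3 (0.04 log units; within the scatter)), so the ring and its hydrogen-bond acceptor are not needed here to hold this level. The propanoylamino group also leaves the gap in place (a 6.3-fold higher number from compound 1 to compound 3 (0.80 log units; beyond the scatter)), much as the ((oxan-4-yl)carbonyl)amino group did, so this gap does not depend on which of these two groups sits on the carbonyl carbon. Nothing at hand gives a reason for either result.

Open, on these data alone, is whether a longer chain such as butyl, a carboxylic acid or an amine on this carbonyl carbon would stay level with compound 2 and compound 3. Also open, as far as these compounds go, is which part of the group in compound 1 carries its gap to the other two.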